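Taking the Chain Back Towards a Longer Group

This account rests on a few compounds, and the source may have more. Where it says the series, first, only, none or still open, it means among the compounds named here.

Among the measured compounds shown here, in a functional assay on SNU-423 cells (Homo sapiens) for inhibition, read by MTT assay, with a stated time of 72 h (on this read-out higher numbers stand for weaker inhibition and lower numbers for stronger inhibition), compound 2 `Nc1nc2cc(-c3nn(CCCCCC(=O)NO)c4ncnc(N)c34)ccc2o1` gives 12600 nM, the only true number so far. Compound 1 `Nc1nc2cc(-c3nn(CCCCCCCCCC(=O)NO)c4ncnc(N)c34)ccc2o1` gives > 50000 nM, which is a limit of the assay and not a number. Compound 3 `Nc1nc2cc(-c3nn(CCCCCCCCC(=O)NO)c4ncnc(N)c34)ccc2o1` has 3-(hydroxycarbamoyl)propyl in place of hydroxycarbamoyl on a saturated chain carbon, five bonds along the chain from an aromatic nitrogen. For the measured compounds named here, one measured step bears on this change, an at least 3.9-fold lower number from compound 1 to compound 2 (0.59 log units; beyond the scatter), which swapped 4-(hydroxycarbamoyl)butyl for hydroxycarbamoyl at that same place. Compound 3 goes most of the way back towards the group of compound 1, so a higher number, meaning weaker inhibition, is expected in this assay. The expected change is a 2.4-fold higher number from compound 2 to compound 3 (0.38 log units; beyond the scatter). For compound 3 the estimated value is 30000 nM, with an expected range from 13000 nM to 50000 nM.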

Compound 3, half-maximal inhibitory concentration: 4940 nM
Estimate against measurement, compound 3: 6.1-fold (0.78 log units) above; measured number below the stated range.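

Chain length at this position does not act in one direction. In this assay, 3-(hydroxycarbamoyl)propyl in place of hydroxycarbamoyl on a saturated chain carbon, five bonds along the chain from an aromatic nitrogen, gives a 2.6-fold lower number from compound 2 to compound 3 (0.41 log units; beyond the scatter), which makes compound 3 the strongest of the three, while compound 2 and compound 1 both fall short of it. Hydroxycarbamoyl in place of (hydroxycarbamoyl)methyl, eight bonds along the chain from an aromatic nitrogen, then gives an at least 10-fold lower number from compound 1 to compound 3 (1.00 log units; beyond the scatter), and the size of this step stays open because compound 1 carries a limit of the assay and not a number: the limit of > 50000 nM in this assay, at which 1 of the 3 values shown sits.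

Three chains cannot show whether one of intermediate length would give a still lower number. As far as these compounds go, whether a carboxylic acid or an amine at the chain end would keep any inhibition also stays open.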